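Extending the amide chain of a coumarin-bearing pyrazoline

This account rests on a few compounds, and the source may have more. Where it says the series, first, only, none or still open, it means among the compounds named here.

Measured so far in a functional assay on PC-3 cells (Homo sapiens) for cytotoxicity, read by MTT assay, with a stated time of 48 h; a higher number here means a weaker inhibitor, a lower number a stronger inhibitor:
- compound 1, `CC1=NN(C(=O)CN2CCCC2)C(c2ccccc2O)C1`, gives 6670 nM
- compound 2, `CC(=O)Oc1ccccc1C1CC(C)=NN1C(=O)CCl`, gives 3580 nM
- compound 3, `CCC(=O)N1N=C(c2cc3ccccc3oc2=O)CC1c1ccccc1`, gives 4370 nM

Compound 3 has the second highest of the three numbers, but its distances to compound 2 and to compound 1 both lie within the usual scatter, so the three cannot be ranked. Compound 4, `CC1CCCCN1CC(=O)N1N=C(c2cc3ccccc3oc2=O)CC1c1ccccc1`, differs from compound 3 in one place: 2-methylpiperidin-1-yl in place of methyl on a saturated chain carbon bound to a carbonyl carbon. Among the measured compounds shown here, no measured pair shows the effect of such a change, so only an expectation can be given. Compound 1, which also carries a saturated amine ring on the acetyl chain, gives 6670 nM, a number not far from the others. A step from compound 3 no larger than the scatter, a 1.1-fold higher number from compound 3 to compound 4 (0.06 log units; within the scatter), is expected. Compound 4 is estimated at 5000 nM, between 2000 nM and 14000 nM.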

Compound 4, half-maximal inhibitory concentration: 36300 nM
Estimate against measurement, compound 4: 7.3-fold (0.86 log units) below, and the stated range ends below it.
By their numbers in this assay, from the lowest: compounds 2, 3 and 1 (each within the scatter of the next); then compound 4.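

On the saturated chain carbon bound to a carbonyl carbon, 2-methylpiperidin-1-yl in place of methyl is far from a neutral swap: this assay shows an 8.3-fold higher number from compound 3 to compound 4 (0.92 log units; beyond the scatter) on the shared core. This position therefore does not accept this added ring without a clear loss of activity. Nothing measured here accounts for that loss. Open, going by these compounds, is whether the ring or its methyl matters, which piperidin-1-yl would test on the same carbon. A small open-chain amine such as dimethylamino, or a carboxylic acid, could also show whether any group there gives a similar loss.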